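Adding a 3-(dimethylamino)propoxy group to compound 3

This account rests on a few compounds, and the source may have more. Where it says the series, first, only, none or still open, it means among the compounds named here.

In a functional assay on SK-BR-3 cells (Homo sapiens) for antiproliferative activity (a lower number here means a stronger inhibitor, a higher number a weaker inhibitor), compound 3 (`CC(C)=CCc1cccc(C(=O)Nc2cc3ccc(OC4CCN(C)CC4)c(C)c3oc2=O)c1`) gives 1680 nM and lies within the scatter of compound 1 (`CCCCOc1ccc(C(=O)Nc2cc3ccc(OC4CCN(C)CC4)c(C)c3oc2=O)cc1CC=C(C)C`) at 1400 nM and of compound 2 (`C#CCOc1ccc(C(=O)Nc2cc3ccc(OC4CCN(C)CC4)c(C)c3oc2=O)cc1CC=C(C)C`) at 1400 nM. Compound 4 (`CC(C)=CCc1cc(C(=O)Nc2cc3ccc(OC4CCN(C)CC4)c(C)c3oc2=O)ccc1OCCCN(C)C`) has 3-(dimethylamino)propoxy in place of hydrogen on an aromatic carbon, ortho to a 3-methylbut-2-en-1-yl group: 3-(dimethylamino)propoxy in place of hydrogen on an aromatic carbon. Among the compounds with values here, two measured steps concern this same carbon: a 1.2-fold higher number from compound 1 to compound 3 (0.08 log units; within the scatter) and a 1.2-fold higher number from compound 2 to compound 3 (0.08 log units; within the scatter). Both lie within the scatter, as does no change at the digits printed from compound 1 to compound 2 (within the scatter). Within the data shown here, neither compound 1 nor compound 2 carries a dimethylamino group, so the data hold no direct precedent for it. The expected step, none beyond the scatter, is a 1.3-fold lower number from compound 3 to compound 4 (0.11 log units; within the scatter). For compound 4 the estimated value is 1300 nM, within an expected range of 480 nM to 3500 nM.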

Compound 4, half-maximal inhibitory concentration: 250 nM
Compound 4: the middle estimate sits 5.2-fold (0.72 log units) above what was measured; measured number outside the range, below it.
By their numbers in this assay, from the lowest: compound 4; then compounds 1, 2 and 3 (each within the scatter of the next).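

In this assay, the aromatic carbon ortho to a 3-methylbut-2-en-1-yl group proves sensitive to what it carries: 3-(dimethylamino)propoxy gives a 6.7-fold lower number from compound 3 to compound 4 (0.83 log units; beyond the scatter), whereas butoxy in compound 1 and propargyloxy in compound 2 stay within the scatter of hydrogen. Dimethylamino in place of the end methyl of butoxy gives a 5.6-fold lower number from compound 1 to compound 4 (0.75 log units; beyond the scatter), and the step from the propargyloxy ether is similar, with a 5.6-fold lower number from compound 2 to compound 4 (0.75 log units; beyond the scatter). Nothing measured here explains this gain. From the compounds shown here alone, it remains open whether a shorter 2-(dimethylamino)ethoxy chain, a morpholine or a terminal hydroxyl would do the same.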